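Replacing 2-methylphenyl with thiophen-2-yl in compound 1

A few compounds are considered here, and "the series" means these few. Any claim that something is new, unique, unknown or untested is made for them only; others in the source may bear on it.

Compound 1 `COC1=C(C)C(=O)/C(=C(O)/C=C/c2ccccc2C)C(=O)C1(C)C`: 4.6 ug/mL
Compound 2 `COC1=C(C)C(=O)/C(=C(O)/C=C/c2c(C)cc(C)cc2C)C(=O)C1(C)C`: 8 ug/mL
Compound 3 `COC1=C(C)C(=O)/C(=C(O)/C=C/c2cccc3ccccc23)C(=O)C1(C)C`: 3.6 ug/mL

In a functional assay on A549 cells (Homo sapiens) for cytotoxicity (a lower number here means that less compound is needed, a higher number that more compound is needed for the effect), compound 1 gives 4.6 ug/mL, and this value lies within the scatter of both compound 2 at 8 ug/mL and compound 3 at 3.6 ug/mL. Compound 4 `COC1=C(C)C(=O)/C(=C(O)/C=C/c2cccs2)C(=O)C1(C)C`, not yet measured, shares the core of compound 1 but carries thiophen-2-yl in place of 2-methylphenyl on a double-bonded chain carbon bound to a double-bonded chain carbon. Among the measured compounds shown here, no two measured compounds differ in one place only, so no direct step guides the expectation. The group on the chain differs among the three measured compounds, yet compound 2 at 8 ug/mL and compound 3 at 3.6 ug/mL both stay within the scatter of compound 1. No step beyond the scatter is therefore expected in this assay, and no direction is favoured. The estimated change is a 1.1-fold higher number from compound 1 to compound 4 (0.04 log units; within the scatter). For compound 4 the estimated value is 5 ug/mL, with an expected range from 2.5 ug/mL to 11 ug/mL.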

Compound 4, concentration for half-maximal effect: 4.5 ug/mL
Estimate against measurement, compound 4: 1.1-fold (0.05 log units) above; the measured number falls inside the stated range.
By their numbers in this assay, from the lowest: compounds 3, 4, 1 and 2 (each within the scatter of the next, the first and the last beyond it).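

In this assay, among the compounds shown here, putting thiophen-2-yl in place of 2-methylphenyl on a double-bonded chain carbon bound to a double-bonded chain carbon gives a 1.0-fold lower number from compound 1 to compound 4 (0.01 log units; within the scatter) and so provides the first comparison in this set that differs in one place only. At this place, a six-membered aromatic ring of carbon only can therefore be exchanged for a five-membered aromatic ring with 1 hetero atom, going from 7 heavy atoms to 5 and bringing in sulfur, with no step beyond the scatter. Nothing available here accounts for this result.

The compounds shown leave open whether this place also tolerates a group that is not an aromatic ring, such as a longer alkyl chain. They also leave open whether an amine or a carboxylic acid on the thiophen-2-yl ring would keep the number within the scatter of compound 1.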